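Swapping the Aryl Group on a Piperazine Amide

This account rests on a few compounds, and the source may have more. Where it says the series, first, only, none or still open, it means among the compounds named here.

The three compounds share one core and differ only in the amine joined through the amide on the ring nitrogen. Compound 1, `CC1(c2ccccc2)CC(=O)N(CC(=O)N2CCOCC2)C1=O`, carries a morpholine there, and in a functional assay on the whole organism (strain CD-1) with Mus musculus as the target, with a stated time of 2 h (a lower number here means that less compound is needed, a higher number that more compound is needed for the effect), compound 1 gives 300 mg/kg. Compound 2, `CC1(c2ccccc2)CC(=O)N(CC(=O)N2CCN(c3cccc(C(F)(F)F)c3)CC2)C1=O`, carries a piperazine bearing a 3-(trifluoromethyl)phenyl; in this assay compound 2 gives "not active" (no number reported), so no single number places it on the scale, and it stands only as a compound for which no effective dose was found.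

Compound 3, `CC1(c2ccccc2)CC(=O)N(CC(=O)N2CCN(c3ccc(F)cc3)CC2)C1=O`, has not yet been tested. It differs from compound 2 in one place: 4-fluorophenyl in place of 3-(trifluoromethyl)phenyl on an amine nitrogen in a ring. The change keeps the ring amine and the aryl substituent, and only the aryl portion is smaller. Among the measured compounds shown here, no measured pair shows what such a swap does in this assay, so the direction of the step is open; with compound 2 lacking a number and compound 1 giving 300 mg/kg, a weak result of similar size, or again none, seems the most likely outcome. Compound 3 is therefore expected to give roughly 300 mg/kg in this assay, within 100 mg/kg to 1000 mg/kg, with a fair chance that no effect is found at all.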

Compound 3, minimum effective dose: "not active" (no number reported)
Nothing numeric was reported for compound 3; no gap can be computed for the estimate.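

Compound 2 and compound 3 both lack a number in this assay and so no step can be read between them. Nothing measured here bears on this outcome. The compounds shown leave open whether any aryl group at this place on the amide amine can give an effective dose in this assay.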